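A few compounds are considered here, and "the series" means these few. Any claim that something is new, unique, unknown or untested is made for them only; others in the source may bear on it.

Measured so far:
compound 1 `Cc1cc(/C=C2\C(=O)Nc3ccc(C(=O)c4ccco4)cc32)cc(C)c1O`: 9%
compound 2 `CN(C)C(=O)c1ccc2c(c1)/C(=C/c1cc(Cl)c(O)c(Cl)c1)C(=O)N2`: 15.3%

In an assay on HeLa cells for inhibition of Kinesin-like protein KIF15 (Homo sapiens), read by microscopy, with stated times of 2 s and 20 s, tested at 750 nM (a lower number here means less inhibition, a higher number more inhibition at the concentration tested (going by the name of the read-out)), compound 1 gives 9% and compound 2 gives 15.3%. Compound 2 holds the higher of the two numbers, but its gap to compound 1 lies within the scatter of repeated runs, so the two cannot be ordered on these data; both sit low on the inhibition scale at the single concentration tested. Compound 2 is the starting point for compound 3 `O=C1Nc2ccc(-c3ccccn3)cc2/C1=C/c1cc(Cl)c(O)c(Cl)c1`, which differs from it in one place: pyridin-2-yl in place of dimethylcarbamoyl on an aromatic carbon. The change sits on an aromatic carbon of the six-membered ring of carbon only within the fused system, meta to a fused ring and para to a fused ring. Going by the values given here, no step between two measured compounds isolates a change of this kind, so there is no measured guide to its size or direction. With both measured numbers low and close, the working assumption for this assay is a step of about the scatter in either direction, with a modest allowance for a larger move given that the dimethylcarbamoyl gives way to a ring. The expected step is a number 2.7 percentage points higher from compound 2 to compound 3 (within the scatter). Compound 3 is expected to give 18% in this assay, with a range from 3% to 45%.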

Compound 3, a percentage reported as inhibition, at one concentration (the size of the read-out at that concentration, not a potency): 7.3%
Compound 3: middle estimate off by 10.7 percentage points, on the high side, within the range that was stated.
By their numbers in this assay, from the lowest: compounds 3, 1 and 2 (each within the scatter of the next).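

In this assay, going by these compounds alone, the pyridin-2-yl in place of dimethylcarbamoyl on this aromatic carbon, meta to a fused ring and para to a fused ring, gives a number 8 percentage points lower from compound 2 to compound 3 (within the scatter) and this is the only measured step at this position. It shows that an aromatic ring carrying one hetero atom and an open-chain amide group can stand at this carbon with no step beyond the scatter, so compound 2 and compound 3 cannot be ordered, and the readings at the single concentration tested stay low for both. No measurement shown here explains how either group acts at this carbon.

From the compounds shown here alone, whether a carboxylic acid, an amine, a plain phenyl or a pyridin-3-yl at this carbon would give a step beyond the scatter stays open, and so does whether any group here could lift inhibition clear of the low readings of compound 2 and compound 3. Also open, going by these compounds, is whether this step would hold with other substituents on the hydroxyphenyl part of the shared core, such as methyl or bromo in place of the two chlorines.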